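The source may hold more compounds than are shown below. What is called first, only, known or untested is meant among the compounds shown, and "the series" means these compounds.

Three compounds of one series have been run through a functional assay on HCC1806 cells (Homo sapiens) for inhibition, read by sulforhodamine B assay, tested at 10 uM (on this read-out lower numbers stand for less inhibition and higher numbers for more inhibition at the one concentration tested (going by the name of the read-out)), so far: compound 1 `CN1CCN(c2ccc(C3=NN(C(=O)CCCl)C(c4ccc(N(C)C)cc4)C3)cc2)CC1`, compound 2 `CN(C)c1ccc(C2CC(c3ccc(-n4cncn4)cc3)=NN2C(=O)c2cc(Cl)cc(Cl)c2)cc1` and compound 3 `C=C(C)C(=O)N1N=C(c2ccc(-n3ccnc3)cc2)CC1c1ccc(N(C)C)cc1`. In this assay compound 1 gives 1.7%. In this assay compound 2 gives 5.3%. In this assay compound 3 gives 1.6%. Compound 3 holds the lowest of the three numbers, but its nearest neighbour, compound 1, and its furthest, compound 2, both sit within the scatter of it, so the three cannot be put in any order: all three show little inhibition at the single concentration tested.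

Compound 4 `Cc1ccc(S(=O)(=O)N2N=C(c3ccc(-n4ccnc4)cc3)CC2c2ccc(N(C)C)cc2)cc1` is the next member and has not yet been measured. It differs from compound 3 in one place:

(4-methylphenyl)sulfonyl in place of (1-methylethenyl)carbonyl on an amine nitrogen in a ring

Within the data shown here, no pair of measured compounds differs by this same change, so the data give no direct reading of what it does. What the data do give is that the three measured compounds, which differ from one another in several places, all land near the bottom of the inhibition scale. On that basis the step from compound 3 to compound 4 is expected to be none beyond the scatter, a number 2.4 percentage points higher from compound 3 to compound 4 (within the scatter). Compound 4 is therefore estimated to give 4% in this assay, somewhere between -6% and 16%.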

Compound 4, a percentage reported as inhibition, at one concentration (the size of the read-out at that concentration, not a potency): 66%
The estimate for compound 4 lay 62 percentage points below the measured number; measured number outside the range, above it.
By their numbers in this assay, from the lowest: compounds 3, 1 and 2 (each within the scatter of the next); then compound 4.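

In this assay, putting (4-methylphenyl)sulfonyl in place of (1-methylethenyl)carbonyl on an amine nitrogen in a ring gives a number 64.4 percentage points higher from compound 3 to compound 4 (beyond the scatter), a large step. Among these compounds, this shows that the group at this position can decide whether the series inhibits at the one concentration tested, something the earlier compounds, all close together near the bottom of the scale, gave no sign of. The change swaps a carbonyl for a sulfonyl, adds a six-membered aromatic ring of carbon only and raises the group from 5 to 10 heavy atoms, and nothing at hand bears on why the number rises.

Among the compounds shown here, the single step cannot say which of these parts matters: a methanesulfonyl group would keep the sulfonyl without the aromatic ring, while a 4-methylbenzoyl group would keep the ring on a carbonyl. Also open, going by these compounds, are the role of the methyl on the ring, which a plain phenylsulfonyl or a 4-chlorophenylsulfonyl group would test, and whether the gain survives when the rest of compound 4 is varied.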